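Chloro in place of methoxy, from compound 2 to compound 3

The compounds below may be only part of what the source reports. "The series", "measured", "known", "first", "only" and "open" are said of these compounds alone.

In an ADME assay on HEK293 cells (Homo sapiens) for cytotoxicity, read by luminescence, with a stated time of 72 h (a higher number here means that more compound is needed for the effect, a lower number that less compound is needed), compound 1 (`CCOC(=O)c1c(-c2cccc(OC)c2)[nH]c2cc(OC)c(Cl)cc2c1=O`) gives > 22000 nM as a limit of the assay, not a number. Compound 2 (`CCOC(=O)c1c(-c2cccc(OC)c2)[nH]c2cc(OC)c(F)cc2c1=O`) gives > 22000 nM as a limit too, so its standing is known only as that limit. With the limit of > 22000 nM in this assay, at which 2 of the 2 values shown sit, as the whole record so far, no number exists yet for either compound. For the measured compounds named here, the one measured step is a step that the two limits leave unreadable from compound 1 to compound 2 and it replaces chloro with fluoro at another group, so it offers no size to carry over.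

The next structure is compound 3 (`CCOC(=O)c1c(-c2cccc(Cl)c2)[nH]c2cc(OC)c(F)cc2c1=O`), which differs from compound 2 by chloro in place of methoxy on an aromatic carbon and reads as 3-methoxyphenyl to 3-chlorophenyl, chloro in place of methoxy on an aromatic carbon, meta to a large group. No readable step supports a shift of any size, so in this assay no change beyond the scatter is expected, and compound 3 will most likely be reported as a limit again. The estimated step is a number no higher from compound 2 to compound 3 (the limit leaves the size open) and it remains only an expectation. For compound 3 the estimated value is 22000 nM with an expected range from 9000 nM to 50000 nM in this read-out.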

Compound 3, half-maximal effective concentration: > 22000 nM
Compound 3 gave a limit, no number; the forecaster's own chance of this, stated with the estimate: 75%; the middle value sits exactly at the limit.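

In this assay compound 3 gives > 22000 nM, a limit and not a number. Compound 2 also stands at a limit, so no step can be read between compound 2 and compound 3. The compounds shown leave open whether any of them would give a number in this assay, because all share one limit: the limit of > 22000 nM in this assay, at which 3 of the 3 values shown sit.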